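Ester variation at the carbonyl carbon of a flavanonol series

The source may hold more compounds than are shown below. What is called first, only, known or untested is meant among the compounds shown, and "the series" means these compounds.

Measured so far:
compound 1 `COc1ccc(C(=O)OCC2Oc3ccc([C@H]4Oc5cc(O)cc(O)c5C(=O)[C@@H]4O)cc3OC2c2ccc(O)c(OC)c2)cc1` — 73300 nM
compound 2 `COc1cc(C2Oc3cc([C@H]4Oc5cc(O)cc(O)c5C(=O)[C@@H]4O)ccc3OC2COC(=O)c2ccccc2)ccc1O` — 105000 nM
compound 3 `CCOC(=O)CC(=O)OCC1Oc2ccc([C@H]3Oc4cc(O)cc(O)c4C(=O)[C@@H]3O)cc2OC1c1ccc(O)c(OC)c1` — 101000 nM

All three values come from a functional assay, read by spectrophotometry, with a stated time of 30 min; a higher number here means that more compound is needed for the effect, a lower number that less compound is needed. The three numbers lie close together: the step of a 1.4-fold higher number from compound 1 to compound 3 (0.14 log units; within the scatter) and the step of a 1.4-fold higher number from compound 1 to compound 2 (0.16 log units; within the scatter) both stay within the scatter, so compound 1 cannot be set apart from compound 2 or compound 3 on these data; the three are one cluster.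

Compound 4 `COc1cc(C2Oc3cc([C@H]4Oc5cc(O)cc(O)c5C(=O)[C@@H]4O)ccc3OC2COC(=O)/C=C/c2ccc(Cl)cc2)ccc1O` is not yet measured. Relative to compound 1 it differs as follows: 2-(4-chlorophenyl)ethenyl in place of 4-methoxyphenyl on a carbonyl carbon. The measured steps that touch the same place are a 1.4-fold higher number from compound 1 to compound 3 (0.14 log units; within the scatter) and a 1.0-fold lower number from compound 2 to compound 3 (0.02 log units; within the scatter), each within the scatter, and the change at the aromatic carbon, a 1.4-fold higher number from compound 1 to compound 2 (0.16 log units; within the scatter), was also within the scatter. Exchanges at the carbonyl carbon have so far left this assay unmoved, so no step beyond the scatter is expected from compound 1 to compound 4, in either direction; the estimated step is a 1.2-fold higher number from compound 1 to compound 4 (0.06 log units; within the scatter). Compound 4 is therefore expected to give about 85000 nM in this assay, with a range from 35000 nM to 210000 nM.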

Compound 4, half-maximal effective concentration: 87900 nM
The estimate for compound 4 lay 1.0-fold (0.01 log units) below the measured number, within the range that was stated.
By their numbers in this assay, from the lowest: compounds 1, 4, 3 and 2 (each within the scatter of the next).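

In this assay, the 2-(4-chlorophenyl)ethenyl ester falls in the same cluster as the earlier esters (a 1.2-fold higher number from compound 1 to compound 4 (0.08 log units; within the scatter); a 1.1-fold lower number from compound 3 to compound 4 (0.06 log units; within the scatter); a 1.2-fold lower number from compound 2 to compound 4 (0.08 log units; within the scatter)). This extends the tolerance at this carbonyl carbon to a group that carries chlorine and a double bond outside aromatic rings, and that has no hydrogen-bond acceptor, with no step beyond the scatter. No supporting measurement is available to explain this flat response.

As far as these compounds go, whether a carboxylic acid or an amine at the far end of the ester group would give a step beyond the scatter remains open. So does whether a longer chain at this carbonyl carbon would leave the number in the same cluster.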